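A Methoxy Addition on a Flat Cytotoxicity Series

The source may report more compounds than this note shows. Statements on the series, on what has been measured and on what is new or still open speak of the compounds shown alone.

Compound 1 `CN(C)c1nc(NNC(=O)Nc2cc(Cl)nc(Cl)c2)nc2c1ccn2C`, compound 2 `O=C(Nc1cc(Cl)cc(Cl)c1)Nc1cc(Cl)nc(Cl)c1` and compound 3 `O=C(Nc1ccnc(Cl)c1)Nc1cc(Cl)nc(Cl)c1` share the same core and differ only in the group carried on one side of it. In an ADME assay on NCM460 cells (Homo sapiens) for cytotoxicity, read by MTT assay, with a stated time of 72 h, in the presence of a further agent that is not named here (a higher number here means that more compound is needed for the effect, a lower number that less compound is needed), compound 1 gives 58500 nM, compound 2 gives 55400 nM, and compound 3 gives 55300 nM. Compound 3 holds the lowest of the three numbers, but its nearest neighbour, compound 2, stands within the scatter, and so does compound 1, the furthest of the three; on these numbers the three compounds cannot be told apart.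

Compound 4 `COc1cc(NC(=O)Nc2cc(Cl)nc(Cl)c2)cc(Cl)n1` has not yet been measured. It differs from compound 3 by methoxy in place of hydrogen on an aromatic carbon. For the measured compounds named here, no step between measured compounds that changes a single place is available, so the effect of this change must be judged from the flat picture alone: three different partners on the other side of the shared core have left this assay unchanged. Compound 4 is therefore expected to stay close, with a step of a 1.0-fold lower number from compound 3 to compound 4 (0.00 log units; within the scatter) that is expected to fall within the scatter in either direction. The estimate for compound 4 in this assay is 55000 nM, with an expected range from 28000 nM to 110000 nM.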

Compound 4, half-maximal effective concentration: 33200 nM
Estimate against measurement, compound 4: 1.7-fold (0.22 log units) above, and the stated range covers the measured number.
By their numbers in this assay, from the lowest: compounds 4, 3, 2 and 1 (each within the scatter of the next).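

For the compounds shown here, this is the first step that changes a single place, and in this assay it reads a 1.7-fold lower number from compound 3 to compound 4 (0.22 log units; within the scatter) for methoxy in place of hydrogen on an aromatic carbon. The earlier compounds shown here varied only the partner on the other side of the shared core, whereas this step concerns a position on a six-membered aromatic ring with 1 nitrogen, next to the ring nitrogen and meta to a chloro group, and here a group of 2 heavy atoms in place of hydrogen leaves the number within the scatter. Nothing measured alongside these numbers bears on this result.

The compounds shown leave open whether an amine, a carboxylic acid or a longer chain at this same position would also stay within the scatter, or whether a larger group would move the number beyond it. They also leave open whether methoxy at this position would give a step of the same size when paired with a different partner on the other side of the shared core.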